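From compound 2 to compound 4: methyl for isopropyl

The source may report more compounds than this note shows. Statements on the series, on what has been measured and on what is new or still open speak of the compounds shown alone.

Within the data shown here, in a functional assay (aorta) for inhibition, with Rattus norvegicus as the target (a higher number here means a weaker inhibitor, a lower number a stronger inhibitor), compound 1 (`CC(C)(C)/N=C(\NC#N)Nc1ccc(C#N)cc1`) gives 530 nM as the lowest number so far. Compound 2 (`CC(C)/N=C(\NC#N)Nc1ccc(C#N)cc1`) gives 19000 nM and sits within the scatter of compound 3 (`CCC(C)(C)/N=C(\NC#N)Nc1cccc(S(=O)(=O)N2CCCCC2)c1`) at 12800 nM in the same assay, so these two share the weak end of the set. Among the measured compounds shown here, compound 4 (`C/N=C(\NC#N)Nc1ccc(C#N)cc1`) carries methyl in place of isopropyl on a double-bonded nitrogen as its one change, methyl in place of isopropyl on a double-bonded nitrogen. For the measured compounds named here, only one measured step bears on this: a 36-fold higher number from compound 1 to compound 2 (1.55 log units; beyond the scatter) is large and also removes a methyl from the group on that nitrogen. A further rise is therefore expected, given here as a 3.2-fold higher number from compound 2 to compound 4 (0.50 log units; beyond the scatter) and smaller than that step. For compound 4 the estimate is 60000 nM (range 15000 nM to 200000 nM).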

Compound 4, half-maximal inhibitory concentration: 130000 nM
For compound 4 the middle estimate is 2.2-fold (0.34 log units) below the measured one; the range from low to high includes it.
By their numbers in this assay, from the lowest: compound 1; then compounds 3 and 2 (each within the scatter of the next); then compound 4.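

Replacing isopropyl with methyl on a double-bonded nitrogen extends the loss seen on removing a methyl from tert-butyl (a 6.8-fold higher number from compound 2 to compound 4 (0.84 log units; beyond the scatter)) in this assay. The overall change from tert-butyl to methyl at this place is much larger (a 250-fold higher number from compound 1 to compound 4 (2.39 log units; beyond the scatter)), so compound 1, compound 2 and compound 4 form an unbroken order from tert-butyl through isopropyl to methyl. Nothing measured here accounts for this order.

As far as these compounds go, whether a longer chain or cyclohexyl at this place would extend the order beyond tert-butyl remains open. So does the effect of an amine-bearing chain there.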